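Swapping the aryl group of a weak cell-growth inhibitor

A few compounds are considered here, and "the series" means these few. Any claim that something is new, unique, unknown or untested is made for them only; others in the source may bear on it.

Three compounds share a core in which a sulfur-linked three-carbon chain joins a five-membered aromatic ring to a piperazine carrying a fused bicyclic group. In a functional assay on A-431 cells (Homo sapiens) for inhibition, read by MTT assay, with a stated time of 72 h (on this read-out higher numbers stand for weaker inhibition and lower numbers for stronger inhibition), compound 1 `COc1ccc(-c2nnc(SCCCN3CCN(c4nc5ccccc5o4)CC3)o2)cc1` gives 52700 nM. Compound 2 `Oc1ccc(-c2nnc(SCCCN3CCN(c4nc5ccccc5o4)CC3)o2)cc1` gives 117000 nM in this assay, and compound 3 `COc1ccc(-c2nnc(SCCCN3CCN(c4nc5ccccc5s4)CC3)o2)cc1` gives 56200 nM. Compound 3 therefore stands second highest of the three numbers; its nearest neighbour is compound 1 within the scatter, and compound 2 lies furthest, beyond the scatter.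

Compound 4 `O=C(NCc1nnc(SCCCN2CCN(c3nc4ccccc4s3)CC2)o1)c1ccccc1` differs from compound 3 in one place: benzamidomethyl in place of 4-methoxyphenyl on an aromatic carbon. Of the two known steps, a 2.2-fold higher number from compound 1 to compound 2 (0.35 log units; beyond the scatter) touches the same aryl group but changes only its oxygen substituent, while a 1.1-fold higher number from compound 1 to compound 3 (0.03 log units; within the scatter) concerns the fused bicyclic group at the other end of the molecule. Neither step removes the aryl group itself, so the data give no direct measure of what replacing it entirely should do. Because a 1.1-fold higher number from compound 1 to compound 3 (0.03 log units; within the scatter) was small and a 2.2-fold higher number from compound 1 to compound 2 (0.35 log units; beyond the scatter) was only modest, compound 4 is expected to stay in the same weak range, with the step of a 1.2-fold higher number from compound 3 to compound 4 (0.06 log units; within the scatter) estimated to be small but carrying wide uncertainty. Compound 4 is thus estimated at 65000 nM, within 15000 nM to 280000 nM.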

Compound 4, half-maximal inhibitory concentration: 55900 nM
Compound 4: middle estimate off by 1.2-fold (0.07 log units), on the high side, within the range that was stated.
By their numbers in this assay, from the lowest: compounds 1, 4 and 3 (each within the scatter of the next); then compound 2.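

In this assay, exchanging the whole 4-methoxyphenyl group on the aromatic carbon of the five-membered aromatic ring for benzamidomethyl gives a 1.0-fold lower number from compound 3 to compound 4 (0.00 log units; within the scatter), so this position accepts a quite different group with no change beyond the scatter. The earlier steps shown here altered only the oxygen substituent on the aryl group or the fused bicyclic group at the far end, whereas this one replaces the entire group: the entering group has more heavy atoms, and a double bond outside aromatic rings and a hydrogen-bond donor enter, while a six-membered aromatic ring of carbon only remains. No measurement here explains why the number holds across this exchange.

The compounds shown leave open whether any aromatic ring is needed at this position, as a small methyl group, a primary amine or a carboxylic acid there would test that directly. They also leave open whether benzamidomethyl behaves in the same way alongside 1,3-benzoxazol-2-yl on the piperazine, and whether any group at this position moves the number beyond the scatter.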